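The source may hold more compounds than are shown below. What is called first, only, known or untested is meant among the compounds shown, and "the series" means these compounds.

Compound 1 `CC1CC(=O)N(CC(=O)N2CCN(c3cccc(Cl)c3)CC2)C1=O`: 100 mg/kg
Compound 2 `Cc1ccccc1N1CCN(C(=O)CN2C(=O)CC(C)C2=O)CC1`: 100 mg/kg
Compound 3 `Cc1cccc(N2CCN(C(=O)CN3C(=O)CC(C)C3=O)CC2)c1`: 100 mg/kg

All three were tested in a functional assay on the whole organism (strain CD1) with Mus musculus as the target, with a stated time of 0.5 h; on this read-out lower numbers stand for an effect already at smaller amounts and higher numbers for an effect only at larger amounts of compound. Compound 1 stands level with compounds 2 and 3 on these numbers: the step of no change at the digits printed from compound 1 to compound 2 (within the scatter) and the step of no change at the digits printed from compound 1 to compound 3 (within the scatter) both lie within the scatter, and so does no change at the digits printed from compound 2 to compound 3 (within the scatter). Compound 4 `CC1CC(=O)N(CC(=O)N2CCN(c3ccccc3Cl)CC2)C1=O` differs from compound 1 by 2-chlorophenyl in place of 3-chlorophenyl on an amine nitrogen in a ring. Going by the values given here, the steps that bear on this change are no change at the digits printed from compound 2 to compound 3 (within the scatter), a like shift of a methyl on the same ring, and no change at the digits printed from compound 1 to compound 2 (within the scatter); neither moved beyond the scatter. Compound 4 is therefore expected to give no change at the digits printed from compound 1 to compound 4 (within the scatter), no step beyond the scatter. In this assay compound 4 is estimated at 100 mg/kg, with a range from 50 mg/kg to 200 mg/kg.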

Compound 4, minimum effective dose: 300 mg/kg
Estimate against measurement, compound 4: 3.0-fold (0.48 log units) below; the measured number lies above the stated range.
By their numbers in this assay, from the lowest: compounds 1, 2 and 3 (each within the scatter of the next); then compound 4.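

In this assay, going by these compounds alone, 2-chlorophenyl in place of 3-chlorophenyl gives a 3.0-fold higher number from compound 1 to compound 4 (0.48 log units; beyond the scatter), so the placing of the chloro on this phenyl ring can shift the minimum effective dose beyond the scatter, which the earlier compounds did not show. Compound 4 also stands apart from both methyl compounds, with a 3.0-fold higher number from compound 3 to compound 4 (0.48 log units; beyond the scatter) and a 3.0-fold higher number from compound 2 to compound 4 (0.48 log units; beyond the scatter). Swapping methyl for chloro therefore reads differently on the two phenyl groups: the same change on two cores in this assay, no change at the digits printed (within the scatter) from compound 1 to compound 3 and a 3.0-fold lower number (0.48 log units; beyond the scatter) from compound 4 to compound 2, 3.0-fold (0.48 log units) apart, beyond the scatter of two such steps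

The compounds shown leave open whether a fluorophenyl or a methoxyphenyl on the same amine nitrogen would stand level with compounds 1, 2 and 3 or with compound 4.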